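Shortening the chain on the core of compound 1

The source may hold more compounds than are shown below. What is called first, only, known or untested is meant among the compounds shown, and "the series" means these compounds.

Compound 1 `CCCCC1Nc2ccccc2C(=O)N1Cc1ccc(-c2ccccc2-c2nn[nH]n2)cc1` is measured in a functional assay on the whole organism for inhibition, with Rattus norvegicus as the target, at a dose of 15 mg/kg by the intravenous route (a higher number here means more inhibition at the dose given (going by the name of the read-out), a lower number less inhibition), where compound 1 gives 88%. Compound 2 `CCCC1Nc2ccc(C(C)C)cc2C(=O)N1Cc1ccc(-c2ccccc2-c2nn[nH]n2)cc1` gives 88% and compound 3 `CCCCC1Nc2ccc(C(C)C)cc2C(=O)N1Cc1ccc(-c2ccccc2-c2nn[nH]n2)cc1` gives 88%, so compound 1 stands level with both. The step to compound 4 `CCC1Nc2ccccc2C(=O)N1Cc1ccc(-c2ccccc2-c2nn[nH]n2)cc1` is hydrogen in place of ethyl on a saturated chain carbon, two bonds along the chain from a saturated ring carbon. The nearest comparison is the chain change no change at the digits printed from compound 2 to compound 3 (within the scatter), which stayed within the scatter; the aromatic change no change at the digits printed from compound 1 to compound 3 (within the scatter) also stayed within it. Since lengthening the chain changed nothing measurable, shortening it is expected to change little, though a small loss cannot be excluded, with a step of a number 8 percentage points lower from compound 1 to compound 4 (within the scatter) expected. Compound 4 is therefore estimated at 80%, with a range from 60% to 95%.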

Compound 4, a percentage reported as inhibition, in the whole organism at one dose (the size of the read-out at that dose, not a potency): 88%
The estimate for compound 4 lay 8 percentage points below the measured number; low and high end bracket the measured number.
By their numbers in this assay, from the lowest: compounds 1, 2, 3 and 4 (each within the scatter of the next).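

Cutting the butyl chain to ethyl gives no change at the digits printed from compound 1 to compound 4 (within the scatter) in this assay, so the shorter chain on this saturated ring carbon holds the read-out as well as the butyl chain does. This adds a shortening step to the earlier lengthening step, and neither moved the number beyond the scatter. Nothing available explains this flat result.

On these data alone, whether a methyl, a cyclopropyl or a chain ending in a carboxylic acid at this position would hold the number stays open. Also open, as far as these compounds go, is whether these chains would differ at a lower dose.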